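A few compounds are considered here, and "the series" means these few. Any claim that something is new, unique, unknown or untested is made for them only; others in the source may bear on it.

Measured so far:
compound 1, `COc1ccc(C2Cc3nccn3C2)cc1`, 27%
compound 2, `Clc1ccccc1C1CCc2nc[nH]c2C1`, 60%
compound 3, `Clc1ccc(C2Cc3nccn3C2)cc1`, 45%

The three compounds were run in a functional assay on CHO cells for agonist activity at Alpha-1A adrenergic receptor (Homo sapiens), read by FLIPR and calcium flux; on this read-out lower numbers stand for smaller maximal responses and higher numbers for larger maximal responses. Compound 2 gives the highest maximal response of the three; its steps to compound 3 and to compound 1 are both beyond the scatter, so it stands clearly above the other two. Compound 3 and compound 1 share a core and differ in one place: methoxy in place of chloro on an aromatic carbon. This change gives a number 18 percentage points lower from compound 3 to compound 1 (beyond the scatter), a modest drop that lies beyond the scatter.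

Compound 4, `COc1ccccc1C1CCc2nc[nH]c2C1`, has not yet been measured in this assay. It is related to compound 2 in the same way: methoxy in place of chloro on an aromatic carbon. The two cores, that of compound 2 and that of compound 3, are not alike, and the difference between them is not broken down here. The place of the change also differs in its surroundings: in the measured pair the methoxy enters para to a group of 8 heavy atoms, whereas in compound 4 it enters ortho to a group of 9 heavy atoms. The change from compound 2 to compound 4 is therefore the same kind of change, not the same change.

For the measured compounds named here, with only one measured instance of this kind of change, on a different core and at a differently placed position, the expectation for compound 4 rests on the single step of a number 18 percentage points lower from compound 3 to compound 1 (beyond the scatter) applied to the value of compound 2, 60%. The step from compound 2 to compound 4 is expected to be about a number 18 percentage points lower from compound 2 to compound 4 (beyond the scatter). Going by the values given here, compound 4 is thus estimated at 42%, with a plausible range from 25% to 60%; the range is wide because the only precedent, a number 18 percentage points lower from compound 3 to compound 1 (beyond the scatter), comes from another core.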

Compound 4, largest response reached (Emax), in percent of the reference or control that the assay uses in the Alpha-1A adrenergic receptor assay: 95%
Beside the measured number, compound 4's estimate is 53 percentage points below it; measured number above the stated range.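

In the Alpha-1A adrenergic receptor assay, methoxy in place of chloro on an aromatic carbon gives a number 35 percentage points higher from compound 2 to compound 4 (beyond the scatter), and set beside the earlier case, the change does not carry from one core to the other, not even in direction: the same change on two cores in the Alpha-1A adrenergic receptor assay, a number 18 percentage points lower (beyond the scatter) from compound 3 to compound 1 and a number 35 percentage points higher (beyond the scatter) from compound 2 to compound 4, 53 percentage points apart, beyond the scatter of two such steps. This does not show what sets the two cases apart: they differ in the core and also in the surroundings of the change, which in compound 4 sits ortho to a group of 9 heavy atoms, and two pairs cannot separate these factors. In a physicochemical assay for lipophilicity, at pH 7.4 (a higher number here means a more lipophilic compound, a lower number a more polar compound), compound 2 gives 3.1 and compound 4 gives 2.8, and with a number 0.30 log units lower from compound 2 to compound 4 (within the scatter) this read-out does not separate the two compounds.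

The compounds shown leave open whether the same exchange on the core of compound 3, placed as it is in compound 4, would follow the step seen on the core of compound 2, and whether methoxy at another carbon of the aromatic ring on the core of compound 2 would keep the large response. Also open, from the compounds shown here alone, is how other groups at the place of the change would read in the Alpha-1A adrenergic receptor assay, such as ethoxy, a hydroxyl or an amine.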